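A few compounds are considered here, and "the series" means these few. Any claim that something is new, unique, unknown or untested is made for them only; others in the source may bear on it.

For the measured compounds named here, compound 1 `CCCCNC(=O)/C=C/c1c(/C=C/c2ccc(OC)cc2)cc(OC)cc1OC` is one of two compounds measured in a functional assay on B16-F10 cells (Mus musculus) for inhibition, read by MTT assay, with a stated time of 48 h (a lower number here means a stronger inhibitor, a higher number a weaker inhibitor), where compound 1 gives 2080 nM. Going by the values given here, its companion, compound 2 `C#CCNC(=O)/C=C/c1c(/C=C/c2ccc(OC)cc2)cc(OC)cc1OC`, gives 8280 nM in this assay, so compound 1 stands with the lowest of the two numbers, and the only measured step, a 4.0-fold higher number from compound 1 to compound 2 (0.60 log units; beyond the scatter), separates it from compound 2.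

Compound 3 `COc1ccc(/C=C/c2cc(OC)cc(OC)c2/C=C/C(=O)N2CCCC2)cc1` has not yet been measured in this assay. It differs from compound 1 in the following way: pyrrolidin-1-yl in place of butylamino on a carbonyl carbon. Among the compounds with values here, the one measured step concerns a different part of the molecule, the saturated chain carbon bound to the amide-type nitrogen, and so bears on this change only loosely; it shows that altering the group beyond the carbonyl moved the number by a modest amount, so a step of comparable or smaller size is a reasonable expectation here, with a somewhat higher number judged slightly more likely than a lower one. Compound 3 is therefore expected to come in at about 3000 nM, with a range of 1200 nM to 8000 nM, a step of a 1.4-fold higher number from compound 1 to compound 3 (0.16 log units; within the scatter).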

Compound 3, half-maximal inhibitory concentration: 9280 nM
For compound 3 the middle estimate is 3.1-fold (0.49 log units) below the measured one; measured number above the stated range.
By their numbers in this assay, from the lowest: compound 1; then compounds 2 and 3 (each within the scatter of the next).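

In this assay, pyrrolidin-1-yl in place of butylamino on the carbonyl carbon gives a 4.5-fold higher number from compound 1 to compound 3 (0.65 log units; beyond the scatter), which shows that the number responds to this exchange even though the heavy-atom count stays the same, while the ring is gained and the hydrogen-bond donor is lost. Set against propargylamino, which keeps the amide hydrogen, pyrrolidin-1-yl gives a 1.1-fold higher number from compound 2 to compound 3 (0.05 log units; within the scatter), so two quite different groups on this carbonyl carbon, one with the amide hydrogen and one without it, end up within the scatter of each other, and keeping that hydrogen is not enough to hold the number at the level of compound 1. Nothing available here accounts for either step.

The compounds shown leave open whether the ring or the missing amide hydrogen matters more, since both change together in the step to pyrrolidin-1-yl; an open-chain diethylamino group or a ring-bearing cyclopentylamino group would pull the two apart. They also leave open how the number moves along the chain, for example with hexylamino, or with a larger ring such as piperidin-1-yl or morpholin-4-yl.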